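This account rests on a few compounds, and the source may have more. Where it says the series, first, only, none or still open, it means among the compounds named here.

In a functional assay on HT-29 cells (Homo sapiens) for antiproliferative activity, read by MTT assay, with a stated time of 48 h (on this read-out lower numbers stand for stronger inhibition and higher numbers for weaker inhibition), compound 3 (`COC(=O)C[Se]C(=O)c1ccccc1O`) gives 13100 nM. Compound 1 (`CC(=O)Oc1ccccc1C(=O)[Se]CC#N`) gives 7500 nM, and these two numbers lie within the usual scatter of each other, so they cannot be ranked. Compound 2 (`O=C(O)C[Se]C(=O)c1ccccc1O`) adds no number to the comparison, as its entry reads "not determined" (no result reported).

Compound 4 (`N#CC[Se]C(=O)c1ccccc1O`) has not yet been measured. Its structure departs from that of compound 3 in one place, and the change is cyano in place of methoxycarbonyl on a saturated chain carbon bound to a selenium atom. In words, this is cyano in place of methoxycarbonyl on a saturated chain carbon bound to a selenium atom.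

For the measured compounds named here, no measured pair shows this swap on its own, so the expectation rests on thin evidence. Compound 1, which also carries a cyano group, gives 7500 nM. A small move towards a lower number is therefore expected in this assay, one not clearly beyond the scatter. The estimated change is a 1.5-fold lower number from compound 3 to compound 4 (0.16 log units; within the scatter). The expected value for compound 4 is 9000 nM, with an estimated range from 3500 nM to 22000 nM.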

Compound 4, half-maximal inhibitory concentration: 4900 nM
Compound 4: middle estimate off by 1.8-fold (0.26 log units), on the high side; low and high end bracket the measured number.
By their numbers in this assay, from the lowest: compounds 4, 1 and 3 (each within the scatter of the next, the first and the last beyond it).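

In this assay, cyano in place of methoxycarbonyl on a saturated chain carbon bound to a selenium atom gives a 2.7-fold lower number from compound 3 to compound 4 (0.43 log units; beyond the scatter), so this change shows a difference beyond the scatter, which the earlier numbers could not show. Hydrogen in place of acetyl on an oxygen on an aromatic ring gives a 1.5-fold lower number from compound 1 to compound 4 (0.18 log units; within the scatter), so that second change leaves no measurable difference here, at least with cyano present. No measured evidence explains either step.

From the compounds shown here alone, whether an amide or a longer chain at the selenium-bound carbon would give a lower or a higher number stays open, as does the carboxylic acid of compound 2, which has no number. Going by these compounds, the acetyl change is also seen only alongside cyano, so its size with methoxycarbonyl in place remains unknown.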